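A few compounds are considered here, and "the series" means these few. Any claim that something is new, unique, unknown or untested is made for them only; others in the source may bear on it.

Compound 3 `O=C(NCc1ccccc1)Oc1ccccc1C(=O)Nc1ccccc1` is tested in an ADME assay on HepG2 cells (Homo sapiens) for cytotoxicity, read by MTT assay (on this read-out lower numbers stand for stronger inhibition and higher numbers for weaker inhibition), and compound 3 returns only a limit of the assay there, > 125000 nM. Compound 1 `O=C(Nc1ccccc1)Oc1ccccc1C(=O)Nc1ccccc1` gives 57700 nM in this assay. The step of an at least 2.1-fold lower number from compound 3 to compound 1 (0.33 log units; beyond the scatter) follows the change (phenyl in place of benzyl on an amide-type nitrogen). Compound 2 `O=C(NCc1ccccc1)Oc1ccc(Cl)cc1C(=O)Nc1ccc(C(F)(F)F)cc1` also reaches only a limit in this assay, > 125000 nM. The difference between the core of compound 2 and that of compound 3 is not broken down here. Compound 4 `O=C(Nc1ccccc1)Oc1ccc(Cl)cc1C(=O)Nc1ccc(C(F)(F)F)cc1` has not yet been measured; it carries the same change as the measured pair, (phenyl in place of benzyl on an amide-type nitrogen), at the same place. Carrying the measured step over is uncertain due to the limit of > 125000 nM in this assay, at which 2 of the 3 values shown sit. The expected step for compound 4 is an at least 1.2-fold lower number from compound 2 to compound 4 (0.09 log units; that floor lies within the scatter), resting on an at least 2.1-fold lower number from compound 3 to compound 1 (0.33 log units; beyond the scatter). Compound 4 is therefore estimated at about 100000 nM in this assay, between 40000 nM and 250000 nM.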

Compound 4, half-maximal inhibitory concentration: 9800 nM
The estimate for compound 4 lay 10-fold (1.01 log units) above the measured number, and the stated range ends above it.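

In this assay, phenyl in place of benzyl on the amide-type nitrogen of the second core gives an at least 12-fold lower number from compound 2 to compound 4 (1.10 log units; beyond the scatter). The change therefore lowers the number on both cores, so its direction carries over in these two pairs, and the steps compare as follows: the same change on two cores in this assay, an at least 2.1-fold lower number (0.33 log units; beyond the scatter) from compound 3 to compound 1 and an at least 12-fold lower number (1.10 log units; beyond the scatter) from compound 2 to compound 4; the limit leaves it open whether they differ. This does not show whether the size of the step carries over, because compound 2 and compound 3 give only limits rather than numbers: the limit of > 125000 nM in this assay, at which 2 of the 4 values shown sit.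

As far as these compounds go, it remains open whether the same direction would hold for a longer chain such as phenethyl, or for a saturated ring such as cyclohexyl, on that nitrogen. From the compounds shown here alone, it also remains open how far the change would carry to cores beyond these two.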